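The compounds below may be only part of what the source reports. "The series", "measured", "known", "first", "only" and "open" are said of these compounds alone.

In a functional assay on MIA PaCa-2 cells (Homo sapiens) for inhibition, read by MTT assay, with a stated time of 48 h (on this read-out higher numbers stand for weaker inhibition of growth and lower numbers for stronger inhibition of growth), compound 1 (`CN1CC[C@H](c2c(O)cc(O)c3c(=O)cc(/C=C/c4ccccc4)oc23)[C@H](O)C1`) gives 2000 nM. Compound 2 (`CN1CC[C@H](c2c(O)cc(O)c3c(=O)cc(/C=C/c4ccc(Cl)cc4)oc23)[C@H](O)C1`), which has a chloro in place of hydrogen on an aromatic carbon, gives 2000 nM, which places it level with compound 1 on the numbers available. The next compound, compound 3 (`CN1CC[C@H](c2c(O)cc(O)c3c(=O)cc(/C=C/c4cccc(Cl)c4)oc23)[C@H](O)C1`), has the same atoms as compound 2, joined differently: 3-chlorophenyl in place of 4-chlorophenyl on a double-bonded chain carbon bound to a double-bonded chain carbon. Among the compounds with values here, only one measured step bears on this change, no change at the digits printed from compound 1 to compound 2 (within the scatter). Within the data shown here, that step involves the 4-chlorophenyl group alone, and no measured compound yet carries 3-chlorophenyl, so the evidence for this change is thin and indirect. Even so, the only chloro substitution tested so far left the growth-inhibition value unmoved, and no large shift is expected from the new placement. In this assay, the estimated step is no change at the digits printed from compound 2 to compound 3 (within the scatter), so no movement in either direction beyond the scatter is expected. For compound 3 the estimated value is 2000 nM, with an expected range from 1000 nM to 4000 nM.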

Compound 3, concentration for 50% growth inhibition: 10000 nM
Compound 3: the middle estimate sits 5.0-fold (0.70 log units) below what was measured, and the stated range ends below it.
By their numbers in this assay, from the lowest: compounds 1 and 2 (each within the scatter of the next); then compound 3.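

In this assay, shifting the chloro from 4-chlorophenyl to 3-chlorophenyl on this double-bonded chain carbon gives a 5.0-fold higher number from compound 2 to compound 3 (0.70 log units; beyond the scatter), so the place of the chloro on the aromatic ring matters here, something compound 2 alone could not reveal. Set against the unsubstituted phenyl group, the picture is the same: one placement of the chloro gives no change at the digits printed from compound 1 to compound 2 (within the scatter), while the other gives a 5.0-fold higher number from compound 1 to compound 3 (0.70 log units; beyond the scatter), which means the earlier flat result holds for 4-chlorophenyl only and not for chloro substitution on this ring in general. Nothing available here explains why the two placements part ways.

The compounds shown leave open whether this weaker inhibition of growth belongs to chloro itself or would also follow from a fluoro or methoxy group put in place of the chloro of compound 3 and of compound 2. They also leave open whether the difference between the two placements would survive if a longer chain replaced the 2-(3-chlorophenyl)ethenyl and 2-(4-chlorophenyl)ethenyl groups.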